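Replacing the chloro of compound 1 with an amide

The source may report more compounds than this note shows. Statements on the series, on what has been measured and on what is new or still open speak of the compounds shown alone.

Within the data shown here, in a functional assay on MDA-MB-231 cells (Homo sapiens) for antiproliferative activity, read by MTT assay, with a stated time of 72 h (on this read-out higher numbers stand for weaker inhibition and lower numbers for stronger inhibition), compound 1 `O=C(Nc1cccc(-c2nc(-c3ccc(NC(=O)c4cccnc4)cc3Cl)no2)c1)Nc1ccc(Cl)c(C(F)(F)F)c1` gives 1900 nM, the only exact number so far. Compound 2 `C#Cc1ccc(NC(=O)Nc2cccc(-c3nc(-c4ccc(NC(=O)c5cccnc5)cc4Cl)no3)c2)cc1` reads > 10000 nM, which is a limit of the assay and not a number. Putting 4-ethynylphenyl in place of 4-chloro-3-(trifluoromethyl)phenyl gives an at least 5.2-fold higher number from compound 1 to compound 2 (0.72 log units; beyond the scatter), a step beyond the scatter. Compound 3 `O=C(Nc1cccc(-c2nc(-c3ccc(NC(=O)c4cccnc4)cc3Cl)no2)c1)Nc1ccc(NC(=O)C2CC2)c(C(F)(F)F)c1` keeps the trifluoromethyl group and has (cyclopropylcarbonyl)amino in place of chloro on an aromatic carbon. Among the measured compounds shown here, the step to compound 2 is the only measured guide, and a loose one, since it replaced the whole group rather than the chloro alone. Its direction suggests a modest move towards weaker inhibition in this assay. The expected change is a 2.1-fold higher number from compound 1 to compound 3 (0.32 log units; beyond the scatter), and this is only an estimate. Compound 3 is expected at about 4000 nM, with an estimated range from 1300 nM to 10000 nM.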

Compound 3, half-maximal inhibitory concentration: 200 nM
For compound 3 the middle estimate is 20-fold (1.30 log units) above the measured one; the whole stated range lies above it.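

In this assay, changing only this one place, with the trifluoromethyl group kept, gives a 9.5-fold lower number from compound 1 to compound 3 (0.98 log units; beyond the scatter), so the position para to a large group and ortho to a trifluoromethyl group accepts a much bigger substituent than chloro, and the number improves rather than worsens. The earlier change replaced the whole 4-chloro-3-(trifluoromethyl)phenyl group, so it could not show what this single position does on its own. Nothing measured here explains why the (cyclopropylcarbonyl)amino group gives the lower number.

On these data alone, it remains open whether the gain rests on the three-membered ring or on the amide link itself. A simple acetylamino group or a plain amine at the same position would separate those two parts, and a longer carbon chain on the carbonyl would show how much room the position allows.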